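Notes on a hydrazone variant of the dimethylaminophenyl series

This account rests on a few compounds, and the source may have more. Where it says the series, first, only, none or still open, it means among the compounds named here.

Two compounds of this series have numbers in a functional assay on MCF7 cells (Homo sapiens) for inhibition, read by MTT assay, with a stated time of 48 h; on this read-out lower numbers stand for stronger inhibition and higher numbers for weaker inhibition. Compound 1 `CCOC(=O)C1=C(N/C=N/c2ncc(-c3ccccc3)s2)Nc2[nH]nc(C)c2C1c1ccc(N(C)C)cc1` gives 10100 nM. Among the compounds with values here, compound 2 `CCOC(=O)C1=C(N/C=N/c2ccc([N+](=O)[O-])cc2)Nc2[nH]nc(C)c2C1c1ccc(N(C)C)cc1` gives 58600 nM, which is the higher of the two, and the only step between them, a 5.8-fold higher number from compound 1 to compound 2 (0.76 log units; beyond the scatter), shows that exchanging the group on the double-bonded nitrogen moves the read-out by a clear margin.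

Compound 3 `CCOC(=O)C1=C(N/N=C(/C(=O)Br)c2ccc(Cl)cc2)Nc2[nH]nc(C)c2C1c1ccc(N(C)C)cc1` is not yet measured. It differs from compound 2 by a group of 12 heavy atoms (8 carbon, 1 nitrogen, 1 oxygen, 1 chlorine, 1 bromine; one six-membered aromatic ring of carbon only) in place of a group of 11 heavy atoms (7 carbon, 2 nitrogen, 2 oxygen; one six-membered aromatic ring of carbon only), on an amine nitrogen. The incoming group is a hydrazone carrying a carbonyl bromide and a chlorophenyl ring in place of the nitrophenyl imine.

Within the data shown here, only the step from compound 1 to compound 2 bears on this position, and it concerns a different exchange, so it gives direction for neither side; it does show that the position responds to change. The expectation for compound 3 is therefore a step of uncertain direction, set a little toward the level of compound 1, a 2.9-fold lower number from compound 2 to compound 3 (0.47 log units; beyond the scatter), with wide spread. Compound 3 is estimated at 20000 nM, within 4000 nM to 100000 nM.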

Compound 3, half-maximal inhibitory concentration: 46300 nM
For compound 3 the middle estimate is 2.3-fold (0.36 log units) below the measured one; the range from low to high includes it.
By their numbers in this assay, from the lowest: compound 1; then compounds 3 and 2 (each within the scatter of the next).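

In this assay, the hydrazone carrying a carbonyl bromide and a chlorophenyl ring and the nitrophenyl imine cannot be told apart (a 1.3-fold lower number from compound 2 to compound 3 (0.10 log units; within the scatter)). The position on the amine nitrogen, which did respond in the earlier exchange (a 5.8-fold higher number from compound 1 to compound 2 (0.76 log units; beyond the scatter)), therefore does not respond to every exchange, and two groups of quite different build, each holding one six-membered aromatic ring of carbon only, can read alike. No supporting measurement bears on this sameness of read-out, so its origin stays unexplained.

The compounds shown leave open which part of the incoming hydrazone matters, since the carbonyl bromide and the chlorophenyl ring enter together and a carboxylic acid, an ethyl ester or an unsubstituted phenyl ring in their places would be needed to separate them. They also leave open whether the 5-phenyl-1,3-thiazol-2-yl group of compound 1 owes its place in the series to the thiazole or to its phenyl ring, and whether a group with no aromatic ring at this position, such as a simple alkyl chain, would hold any measurable inhibition.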